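The source may hold more compounds than are shown below. What is called first, only, known or untested is meant among the compounds shown, and "the series" means these compounds.

Going by the values given here, in a functional assay on the whole organism for inhibition, with Rattus norvegicus as the target, at a dose of 30 mg/kg (a higher number here means more inhibition at the dose given (going by the name of the read-out), a lower number less inhibition), compound 1 `N#Cc1cccc(F)c1-c1nc2ncccc2o1` gives 50%, the highest of the two numbers measured so far. Compound 2 `Clc1ccc(-c2nc3ncccc3o2)cc1` gives 24% in this assay, a value that lies below that of compound 1 by more than the usual scatter. Compound 3 `N#Cc1cccc(C#N)c1-c1nc2ncccc2o1` has not yet been tested. It differs from compound 1 by cyano in place of fluoro on an aromatic carbon. Among the compounds with values here, no measured pair shows this change, so its size is unknown; a step from compound 1 to compound 3 of a number 2 percentage points lower from compound 1 to compound 3 (within the scatter) is expected, not beyond the scatter in either direction. Compound 3 is therefore estimated at 48%, with a range from 20% to 75%.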

Compound 3, a percentage reported as inhibition, in the whole organism at one dose (the size of the read-out at that dose, not a potency): 19%
Beside the measured number, compound 3's estimate is 29 percentage points above it; the measured number lies below the stated range.
By their numbers in this assay, from the lowest: compounds 3 and 2 (each within the scatter of the next); then compound 1.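

In this assay, cyano in place of fluoro on this aromatic carbon, ortho to a group of 9 heavy atoms and meta to a cyano group, gives a number 31 percentage points lower from compound 1 to compound 3 (beyond the scatter). Going by these compounds alone, this is the first measured step at this place, and it shows that the inhibition at this dose depends on which of these two groups sits there. Nothing at hand explains the step. On these data alone, it remains open whether an amine or a methoxy group on the same carbon would match compound 1 or fall away as compound 3 does.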